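Hydroxy for hydrogen on the side chain of compound 2

This account rests on a few compounds, and the source may have more. Where it says the series, first, only, none or still open, it means among the compounds named here.

Working notes on a small bromolactone set tested in a functional assay on KB cells (Homo sapiens) for cytotoxicity; a lower number here means that less compound is needed, a higher number that more compound is needed for the effect. Compound 1 `CCC[C@@H](OC(C)=O)C1=C(Br)[C@@](C)(OC)OC1=O` gives 5.4 ug/mL in this assay. Compound 2 `CCCCC1=C(Br)/C(=C/Br)OC1=O` gives only a limit in this assay, > 20 ug/mL. Compound 3 `CCCCC1=C(Br)C(=C(Br)Br)OC1=O` likewise gives only a limit in this assay, > 20 ug/mL. Compound 2 thus stands at the limit of > 20 ug/mL in this assay, at which 2 of the 3 values shown sit. Among the compounds with values here, no pair of the measured compounds differs in a single place, so no measured step is available, and compound 1 shows only that one member of the set gives a number within the range of this assay.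

Compound 4 `CCC[C@@H](O)C1=C(Br)/C(=C/Br)OC1=O` is the next compound to be measured. It differs from compound 2 by hydroxy in place of hydrogen on a saturated chain carbon bound to a double-bonded ring carbon and a saturated chain carbon. Nothing measured in this set shows what such a change does here. Compound 4 is estimated at 12 ug/mL in this assay. The plausible range for compound 4 is expected to run from 4 ug/mL to 30 ug/mL. Expected is a step of an at least 1.6-fold lower number from compound 2 to compound 4 (0.22 log units; that floor lies within the scatter), with a real chance that compound 4 again reports only a limit.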

Compound 4, concentration for half-maximal effect: 0.4 ug/mL
Compound 4: the middle estimate sits 30-fold (1.48 log units) above what was measured, outside the stated range (below it).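

In this assay, within the data shown here, hydroxy in place of hydrogen on a saturated chain carbon bound to a double-bonded ring carbon and a saturated chain carbon gives an at least 50-fold lower number from compound 2 to compound 4 (1.69 log units; beyond the scatter), the first measured step. This carbon of the side chain is therefore a place where a single change is enough to turn a limit into a number within the range of the assay. The size of the step is only a floor, since compound 2 gives a limit and no number: the limit of > 20 ug/mL in this assay, at which 2 of the 4 values shown sit.

On these data alone, whether an amine or a methoxy on the same carbon would give a comparable step stays open, and so does the effect of the opposite configuration at that carbon. As far as these compounds go, it is also open whether hydroxy on this carbon would give a similar step on compound 3.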